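The source may hold more compounds than are shown below. What is called first, only, known or untested is meant among the compounds shown, and "the series" means these compounds.

Working notes on the series. Compound 1 `Cc1cc(-c2nc3cc(F)c(F)cc3s2)ccc1N` is the reference. In a functional assay on cells (Cancer cell lines, Homo sapiens) for inhibition (a higher number here means a weaker inhibitor of growth, a lower number a stronger inhibitor of growth), compound 1 gives < 10 nM, which is a limit of the assay and not a number. Where compound 1 stands is therefore known only in part, because the limit of < 10 nM in this assay, at which 1 of the 2 values shown sits, marks the edge of the measured range. Compound 2 `Nc1ccc(-c2nc3cc(F)ccc3s2)cc1` carries no methyl and a single fluoro; in this assay compound 2 gives 11500 nM. No single step between compound 1 and compound 2 is recorded, so only the two values themselves are shown.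

Compound 3 `Cc1cc(-c2nc3ccc(F)cc3s2)ccc1N` has not yet been measured in this assay. Relative to compound 1 the change is hydrogen in place of fluoro on an aromatic carbon. For the measured compounds named here, no measured step of this kind is available, so the size of the step is an expectation only: a moderate loss of growth inhibition, beyond the scatter but well short of the gap seen for compound 2. Compound 3 is expected to give 30 nM, in the range 5 nM to 300 nM, meaning an estimated step of an at least 3.0-fold higher number from compound 1 to compound 3 (0.47 log units; beyond the scatter).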

Compound 3, concentration for 50% growth inhibition: < 10 nM
Compound 3: no number, only a limit; the forecaster's own chance of this, stated with the estimate: 20%; middle value at least 3.0-fold (0.47 log units) from the limit.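

For the compounds shown here, no step from compound 1 to compound 3 can be read, since both values are limits of the assay and neither is a number: the limit of < 10 nM in this assay, at which 2 of the 3 values shown sit. From the compounds shown here alone, whether hydrogen in place of fluoro on an aromatic carbon changes growth inhibition in this assay remains open.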